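Acetyl position on the anilino ring of compound 1

The source may hold more compounds than are shown below. What is called first, only, known or untested is meant among the compounds shown, and "the series" means these compounds.

Compound 1 `CC(=O)c1cccc(Nc2ccnc(SCC(=O)c3ccc(-c4ccccc4)cc3)n2)c1` gives 18% in a functional assay on NCI-H23 cells (Homo sapiens) for inhibition, read by sulforhodamine B assay, with a stated time of 48 h, tested at 10 uM (a lower number here means less inhibition of growth, a higher number more inhibition of growth at the concentration tested), the lower of the two numbers in hand; compound 2 `COc1ccc(C(=O)CSc2nccc(Nc3cccc(C(C)=O)c3)n2)cc1` gives 19%, and the change a number 1 percentage points higher from compound 1 to compound 2 (within the scatter) lies within the scatter. Compound 3 `CC(=O)c1ccc(Nc2ccnc(SCC(=O)c3ccc(-c4ccccc4)cc3)n2)cc1` differs from compound 1 by 4-acetylphenyl in place of 3-acetylphenyl on a nitrogen on an aromatic ring. For the measured compounds named here, no measured step touches the acetyl position, so nothing in the data speaks for a shift beyond the scatter. Compound 3 is expected to give about 18%, between 5% and 35%, a step of no change at the digits printed from compound 1 to compound 3 (within the scatter) that is an estimate only.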

Compound 3, percent growth inhibition at one concentration: 10%
Compound 3: middle estimate off by 8 percentage points, on the high side, and the stated range covers the measured number.
By their numbers in this assay, from the lowest: compounds 3, 1 and 2 (each within the scatter of the next).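

In this assay, for the compounds shown here, the move to 4-acetylphenyl in place of 3-acetylphenyl on a nitrogen on an aromatic ring gives a number 8 percentage points lower from compound 1 to compound 3 (within the scatter) as the first step at this position. The two acetyl placements therefore cannot be told apart at the concentration tested. No measurement on hand bears on the reason for this result.

From the compounds shown here alone, whether a carboxylic acid or an amine in place of the acetyl would move growth inhibition beyond the scatter remains open. So does the effect of the 4-acetylphenyl change with methoxy in place of phenyl.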